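Methyl to phenyl swaps on the shared core

This account rests on a few compounds, and the source may have more. Where it says the series, first, only, none or still open, it means among the compounds named here.

Measured so far:
compound 1 `CCNC(=O)c1c(-c2ccc(OC)c(OC)c2)csc1N`, 50%
compound 2 `COc1ccc(-c2csc(N)c2C(=O)NCc2ccccc2)cc1OC`, 43%
compound 3 `CCOC(=O)c1c(-c2cccc(C)c2)csc1N`, 77%

In an assay on isolated protein for inhibition of protein kinase C zeta type (Homo sapiens), with stated times of 1 h and 2.5 min, tested at 30 uM (on this read-out lower numbers stand for less inhibition and higher numbers for more inhibition at the one concentration tested (going by the name of the read-out)), compound 1 gives 50%. Compound 2 differs from it by phenyl in place of methyl on a saturated chain carbon bound to an amide-type nitrogen, and the step is a number 7 percentage points lower from compound 1 to compound 2 (within the scatter). Compound 3 gives 77% in this assay, the highest of the three numbers. The difference between the core of compound 1 and the core of compound 3 is not broken down here.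

Compound 4 `Cc1cccc(-c2csc(N)c2C(=O)OCc2ccccc2)c1` is not yet measured. It differs from compound 3 by phenyl in place of methyl on a saturated chain carbon bound to an oxygen next to a carbonyl group. This is the same kind of change as from compound 1 to compound 2, but the place differs: on a saturated chain carbon bound to an oxygen next to a carbonyl group, rather than on a saturated chain carbon bound to an amide-type nitrogen. The step from compound 3 to compound 4 is expected to be a number 7 percentage points lower from compound 3 to compound 4 (within the scatter) because the earlier step was a number 7 percentage points lower from compound 1 to compound 2 (within the scatter). Compound 4 is therefore estimated to give 70% in this assay, between 50% and 85%.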

Compound 4, a percentage reported as inhibition, at one concentration (the size of the read-out at that concentration, not a potency): 68%
Estimate against measurement, compound 4: 2 percentage points above, within the range that was stated.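

In this assay the swap of methyl for phenyl reads a number 9 percentage points lower from compound 3 to compound 4 (within the scatter) and so matches the earlier step on the other core. Carried from one core to the other, the change gives steps that do not differ: the same change on two cores in this assay, a number 7 percentage points lower (within the scatter) from compound 1 to compound 2 and a number 9 percentage points lower (within the scatter) from compound 3 to compound 4, 2 percentage points apart, within the scatter of two such steps

This holds for two cores at one concentration only, and as both steps lie within the scatter, it does not show that the change has a real effect on either core, nor how it would behave on a third core.

The compounds shown leave open whether a longer chain would follow the same course. They also leave open what an amine or a carboxylic acid in place of the phenyl would do in this series.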